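Trimming the chain end: from compound 1 to compound 4

The compounds below may be only part of what the source reports. "The series", "measured", "known", "first", "only" and "open" are said of these compounds alone.

Compound 1 `COC(=O)CC/C=C\CC[C@H]1C(=O)C[C@@H](O)[C@@H]1/C=C/C[C@@](C)(O)/C=C/C=C(C)C` is tested in a functional assay on the whole organism with Rattus norvegicus as the target; a higher number here means that more compound is needed for the effect, a lower number that less compound is needed. In this assay compound 1 reaches only a limit of > 3.16 mg/kg, so no number is known for it. Compound 4 `C/C=C/C=C/[C@](C)(O)C/C=C/[C@H]1[C@H](O)CC(=O)[C@@H]1CC/C=C\CCC(=O)OC` differs from compound 1 in one place: prop-1-en-1-yl in place of 2-methylprop-1-en-1-yl on a double-bonded chain carbon bound to a double-bonded chain carbon.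

Two measured steps start from compound 1. Compound 2 `C/C=C(C)\C=C\[C@](C)(O)C/C=C/[C@H]1[C@H](O)CC(=O)[C@@H]1CC/C=C\CCC(=O)OC` carries 1-methylprop-1-en-1-yl in place of 2-methylprop-1-en-1-yl, and in this assay compound 2 gives 1.23 mg/kg, which amounts to an at least 2.5-fold lower number from compound 1 to compound 2 (0.40 log units; beyond the scatter). Compound 3 `COC(=O)CC/C=C\CC[C@H]1C(=O)C[C@@H](O)[C@@H]1/C=C/C[C@@](C)(O)/C=C/C1=CCCC1` carries cyclopent-1-en-1-yl at the same place. In this assay compound 3 reaches only a limit of > 3.16 mg/kg. As a result there is a step that the two limits leave unreadable from compound 1 to compound 3, while an at least 2.5-fold higher number from compound 2 to compound 3 (0.40 log units; beyond the scatter).

Going by the values given here, the only change from compound 1 with a readable outcome replaced the 2-methylprop-1-en-1-yl with a different small open-chain group and lowered the number; the change to compound 4 likewise replaces it with a small open-chain group, so a downward step is expected, though only one measured step supports this. For compound 4 the estimated value is 1.5 mg/kg, with an expected range from 0.6 mg/kg to 4 mg/kg. This estimate means an expected at least 2.1-fold lower number from compound 1 to compound 4 (0.32 log units; beyond the scatter).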

Compound 4, dose for half-maximal effect: 0.25 mg/kg
For compound 4 the middle estimate is 6.0-fold (0.78 log units) above the measured one; measured number outside the range, below it.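

In this assay, replacing 2-methylprop-1-en-1-yl with prop-1-en-1-yl on this double-bonded chain carbon gives an at least 12-fold lower number from compound 1 to compound 4 (1.10 log units; beyond the scatter), so removing a single methyl group from the chain end can have a large effect. The same group also gives an at least 12-fold lower number from compound 3 to compound 4 (1.10 log units; beyond the scatter), and it outperforms the other open-chain group with a 4.9-fold lower number from compound 2 to compound 4 (0.69 log units; beyond the scatter), which shows that the gain from compound 1 to compound 2 was not the limit at this position. Since all three steps lie beyond the scatter, compound 4 needs the least compound of the four, and the position clearly distinguishes between closely related small groups, even among those without a ring.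

As far as these compounds go, the first two of these steps give only a minimum size, and their full size stays unknown because each starts from a limit rather than a number: the limit of > 3.16 mg/kg in this assay, at which 2 of the 4 values shown sit. From the compounds shown here alone, it remains open whether the double bond of prop-1-en-1-yl matters, which a saturated propyl group would test, and whether a still shorter vinyl group or a longer chain such as pent-1-en-1-yl would lower the number further.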